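The compounds below may be only part of what the source reports. "The series", "measured", "known", "first", "only" and "open" are said of these compounds alone.

Measured compounds so far:
Compound 2 `NC1=NCC(CC2=Cc3ccccc3CC2)O1` — in a functional assay for binding affinity to Norepinephrine transporter (Rattus norvegicus), read by radioligand binding, in the presence of a further agent that is not named here (on this read-out higher numbers stand for weaker inhibition and lower numbers for stronger inhibition), compound 2 gives 1000 nM.
Compound 1 `Cc1ccc2c(c1)CCC(CC1CN=CN1)=C2` — in this assay compound 1 gives < 1000 nM, which is a limit of the assay and not a number.

Within the data shown here, compound 2 is thus the only compound with an actual number in this assay; the other entry is the limit of < 1000 nM in this assay, at which 1 of the 2 values shown sits, so no measured step between the two can be stated, only that each sits around the same mark. Compound 3 `Cc1ccc2c(c1)CCC(CC1CN=C(N)O1)=C2` is compound 2 with one change: methyl in place of hydrogen on an aromatic carbon. Among the measured compounds shown here, no measured pair differs in just this place, so there is no measured step to lean on. The step from compound 2 to compound 3 is expected to be a 1.4-fold lower number from compound 2 to compound 3 (0.15 log units; within the scatter), that is, no change beyond the usual scatter. Compound 3 is therefore estimated to give about 700 nM in this assay, with a likely range from 200 nM to 2500 nM.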

Compound 3, inhibition constant: < 1000 nM
Compound 3 gave a limit, no number; the forecaster's own chance of this, stated with the estimate: 40%; the middle value lies beyond the limit too.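

Placing methyl on this aromatic carbon, in place of hydrogen, gives the first measured information about this position in this assay: a number no higher from compound 2 to compound 3 (the limit leaves the size open). So this small group does not push the number up, but how far it may bring the number down stays hidden because compound 3 gives only a limit of the assay, not a number, and such limits now make up most of the data: the limit of < 1000 nM in this assay, at which 2 of the 3 values shown sit. The step between compound 1 and compound 3 cannot be read, as both values are limits.

On these data alone, what a true number for compound 3 would be remains open. As far as these compounds go, it also remains open whether a chlorine atom, a methoxy group or a longer chain such as ethyl on the same aromatic carbon would move the number in the same direction.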